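The source may hold more compounds than are shown below. What is called first, only, known or untested is meant among the compounds shown, and "the series" means these compounds.

Measured compounds in a functional assay on MT4 cells (Homo sapiens) for cytotoxicity; on this read-out higher numbers stand for lower toxicity in this test and lower numbers for higher toxicity in this test:
Compound 1 `COC(=O)N[C@H](C(=O)NN(Cc1cccc(-c2cccnc2)c1)C[C@@](O)(Cc1ccccc1)C(=O)N[C@H]1c2ccccc2C[C@H]1O)C(C)(C)C` gives 6800 nM.
Compound 2 `COC(=O)N[C@H](C(=O)NN(Cc1cccc(/C=C/c2ccccc2)c1)C[C@@](O)(Cc1ccccc1)C(=O)N[C@H]1c2ccccc2C[C@H]1O)C(C)(C)C` gives only a limit of the assay, > 10000 nM, not a number.

In this assay, higher numbers mean less cytotoxicity on the cells. Compound 2 thus stands at the upper edge of what the assay reports, the less toxic end of the two measured compounds. For the measured compounds named here, the single measured step, an at least 1.4-fold higher number from compound 1 to compound 2 (0.16 log units; that floor lies within the scatter), swaps a pyridin-3-yl for a 2-phenylethenyl group; its true size cannot be known because the limit of > 10000 nM in this assay, at which 1 of the 2 values shown sits, caps the reading for compound 2.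

Compound 3 `COC(=O)N[C@H](C(=O)NN(Cc1cccc(C#Cc2ccccc2)c1)C[C@@](O)(Cc1ccccc1)C(=O)N[C@H]1c2ccccc2C[C@H]1O)C(C)(C)C` differs from compound 2 by one change: 2-phenylethynyl in place of 2-phenylethenyl on an aromatic carbon. Going by the values given here, no measured step bears directly on an alkene-to-alkyne exchange; the only step on record, from compound 1 to compound 2, touches the same position but a different pair of groups and is itself unresolved at the limit. With no sign that this small change should shift toxicity, the step is expected to be none beyond the scatter, a number no higher from compound 2 to compound 3 (the limit leaves the size open). Compound 3 is therefore expected to give about 10000 nM, within 5000 nM to 20000 nM, most likely again reported only as a limit.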

Compound 3, half-maximal cytotoxic concentration: > 10000 nM
Compound 3: only a limit was reported; the forecaster's own chance of this, stated with the estimate: 65%; the middle value sits exactly at the limit.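

In this assay, compound 3 gives > 10000 nM, which is a limit of the assay and not a number. The result shows that the position on the aromatic carbon, meta to a large group, can carry 2-phenylethynyl as well as 2-phenylethenyl with the reading still at the limit, while putting 2-phenylethynyl in place of pyridin-3-yl gives an at least 1.4-fold higher number from compound 1 to compound 3 (0.16 log units; that floor lies within the scatter). The step between 2-phenylethenyl and 2-phenylethynyl cannot be read, and the other steps give only a floor, because compound 2 and compound 3 both sit at the limit: the limit of > 10000 nM in this assay, at which 2 of the 3 values shown sit.

On these data alone, what remains open is how far compound 2 and compound 3 truly lie from compound 1 and from each other, since neither has a number in this assay. Also open, as far as these compounds go, is how this read-out would respond at the same position to 2-phenylethyl, with its chain free of double and triple bonds, or to a group of another kind, such as an amine or a carboxylic acid.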